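This account rests on a few compounds, and the source may have more. Where it says the series, first, only, none or still open, it means among the compounds named here.

Measured compounds:
- compound 1, `COc1ccc(NC(=O)CN2CCN(c3nnc(Cc4ccncc4)c4ccccc34)CC2)cc1OC`: 26500 nM
- compound 2, `O=C(CN1CCN(c2nnc(Cc3ccccc3)c3ccccc23)CC1)Nc1ccc(F)c(F)c1`: 10100 nM

Both compounds were tested in a functional assay on A549 cells (Homo sapiens) for cytotoxicity, read by MTT assay, with a stated time of 72 h; a lower number here means a stronger inhibitor, a higher number a weaker inhibitor. Of the two numbers, compound 1 has the higher one; compound 2 lies at a lower number, and the gap between them is beyond the usual scatter of this measurement. Among the measured compounds shown here, no single-change step between these two measured compounds is available, so the values only show where each one stands.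

The compound that has not yet been measured is compound 3, `O=C(CN1CCN(c2nnc(Cc3ccncc3)c3ccccc23)CC1)Nc1c(F)cccc1F`. It differs from compound 1 in one place: 2,6-difluorophenyl in place of 3,4-dimethoxyphenyl on an amide-type nitrogen. The rest of the molecule, including the shared core and the amide linkage, is the same as in compound 1.

Without a measured step of exactly this kind, the expectation rests on where compound 1 and compound 2 stand. Compound 2, which also carries a difluorophenyl group on the amide-type nitrogen, gives 10100 nM in this assay, a lower number than compound 1. On that basis the step from compound 1 to compound 3 is expected to be a modest move toward a lower number, a 1.8-fold lower number from compound 1 to compound 3 (0.25 log units; within the scatter), possibly no larger than the scatter. Compound 3 is therefore estimated at 15000 nM in this assay, within a range of 5000 nM to 45000 nM.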

Compound 3, half-maximal inhibitory concentration: 54400 nM
For compound 3 the middle estimate is 3.6-fold (0.56 log units) below the measured one, and the stated range ends below it.
By their numbers in this assay, from the lowest: compound 2; then compound 1; then compound 3.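

On the amide-type nitrogen, where the shared core carries its aromatic ring, this assay now offers its first comparison of a single change: putting 2,6-difluorophenyl in place of 3,4-dimethoxyphenyl gives a 2.1-fold higher number from compound 1 to compound 3 (0.31 log units; beyond the scatter). This shows that the group at this position does affect the read-out, although the step is modest and only just clears the usual scatter, and that in this pair a fluorine-bearing ring gives a weaker result than the dimethoxy ring it replaces. No measurement shown here accounts for the direction of this step.

The swap removes both methoxy groups and adds both fluorines in a single move, so this pair cannot separate the effect of what left from the effect of what entered. A plain phenyl ring or a ring with a single methoxy group on this nitrogen would help to divide the step into its two parts, and a ring carrying an amine or a carboxylic acid would show how far the range of groups tolerated here extends.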